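The source may hold more compounds than are shown below. What is called first, only, known or untested is meant among the compounds shown, and "the series" means these compounds.

Going by the values given here, in a functional assay on NCI-H460 cells (Homo sapiens) for inhibition (a lower number here means that less compound is needed, a higher number that more compound is needed for the effect), compound 1 `CC(C(=O)SCCCCCCC(=O)Nc1nc(-c2ccccc2)cs1)c1ccccc1` gives 3200 nM and compound 2 `C[C@H](Cc1ccccc1)C(=O)SCCCCCCC(=O)Nc1nc(-c2ccccc2)cs1` gives 3200 nM, so compound 2 stands level with the only other measured compound. Compound 3 `C[C@@H](Cc1ccccc1)C(=O)SCCCCCCC(=O)Nc1nc(-c2ccccc2)cs1` keeps the structure of compound 2 and changes only its drawn configuration: the two compounds have the same atoms and bonds and differ only in configuration as drawn: 1 of 1 stereo elements differ; a stereocentre at a saturated chain carbon is drawn R in compound 2 and S in compound 3. No atom leaves or enters, so the question is whether reversing this one stereocentre moves the read-out.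

Among the compounds with values here, only one measured step bears on this, and it bears only indirectly. The step of no change at the digits printed from compound 1 to compound 2 (within the scatter) replaces 1-phenylethyl with 1-benzylethyl on a carbonyl carbon, and it stays within the scatter. No measured pair of compounds differs in configuration alone, so the data give no direct measure of what such a change does and no reason to favour either direction. The estimate therefore stays at the level of compound 2, with a wide range to reflect that gap. The expected no change at the digits printed from compound 2 to compound 3 (within the scatter) is estimated to lie within the scatter. Compound 3 is expected at 3200 nM, with an estimated range from 1300 nM to 8000 nM.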

Compound 3, half-maximal effective concentration: 3000 nM
Compound 3: middle estimate off by 1.1-fold (0.03 log units), on the high side; the range from low to high includes it.
By their numbers in this assay, from the lowest: compounds 3, 1 and 2 (each within the scatter of the next).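

In this assay, the change at this saturated chain carbon gives a 1.1-fold lower number from compound 2 to compound 3 (0.03 log units; within the scatter), the first direct measure of what configuration does at this position, and the two drawn forms are not separated by the read-out. This comparison isolates the stereocentre, with no other structural change to account for the result: the fact that compounds 2 and 3 differ only in the configuration as drawn. The step of a 1.1-fold lower number from compound 1 to compound 3 (0.03 log units; within the scatter), which puts 1-benzylethyl in place of 1-phenylethyl on a carbonyl carbon, now stands alongside no change at the digits printed from compound 1 to compound 2 (within the scatter), so both drawn forms of 1-benzylethyl lie within the scatter of 1-phenylethyl.

The compounds shown leave open whether configuration matters equally in the 1-phenylethyl group, which is drawn without a defined configuration in compound 1, so that group offers no comparison of its own. They also leave open whether the read-out would stay level with a longer chain in place of 1-benzylethyl, or with an amine or a carboxylic acid carried on that group.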